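The source may report more compounds than this note shows. Statements on the series, on what has been measured and on what is new or still open speak of the compounds shown alone.

Measured compounds:
Compound 1, `O=C(c1cccc(C#Cc2ccccc2Nc2ncnc3ccc(Cl)nc23)c1)N1CCOCC1`: in an assay on isolated protein for inhibition of MAP kinase-interacting serine/threonine-protein kinase 1 (Homo sapiens), read by HTRF, in the presence of a further agent that is not named here (on this read-out lower numbers stand for stronger inhibition and higher numbers for weaker inhibition), compound 1 gives > 10000 nM, which is a limit of the assay.
Compound 2, `CCCNC(=O)c1cccc(C#Cc2ccccc2Nc2ncnc3ccc(Cl)nc23)c1`: in this assay compound 2 gives > 10000 nM, again a limit.
Compound 3, `O=C(c1cccc(C#Cc2ccccc2Nc2ncnc3ccc(Cl)nc23)c1)N1CCNCC1`: in this assay compound 3 gives > 10000 nM, likewise a limit.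

Compound 3 therefore stands at a limit, not at a number, and so do the two other compounds: the limit of > 10000 nM in this assay, at which 3 of the 3 values shown sit. The step to compound 4, `CN(C)C(=O)c1cccc(C#Cc2ccccc2Nc2ncnc3ccc(Cl)nc23)c1`, is dimethylamino in place of piperazin-1-yl on a carbonyl carbon. The measured steps that bear on it are the two that also swap the group on this carbonyl carbon, a step that the two limits leave unreadable from compound 1 to compound 3 and a step that the two limits leave unreadable from compound 2 to compound 3, together with a step that the two limits leave unreadable from compound 1 to compound 2; none of them can be read, since both ends sit at the limit. Nothing among these compounds shows that any amide variant reaches a measurable number, so for this assay no step beyond the scatter is expected in either direction, and compound 4 is expected to remain at the limit as well: the step that the limit leaves unreadable from compound 3 to compound 4 is the estimated outcome. Compound 4 is expected to give about 15000 nM, within 5000 nM to 50000 nM.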

Compound 4, half-maximal inhibitory concentration: > 10000 nM
Compound 4: only a limit was reported; the forecaster's own chance of this, stated with the estimate: 85%; the middle value lies beyond the limit too.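

In this assay compound 4 gives > 10000 nM, a limit of the assay, so its steps from compound 1, compound 2 and compound 3 cannot be read: the limit of > 10000 nM in this assay, at which 4 of the 4 values shown sit.

The compounds shown leave open whether any group on this carbonyl carbon gives a measurable number in this assay.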